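Sulfonylated chromenone series: antiproliferative read-out on THLE-2

The compounds below may be only part of what the source reports. "The series", "measured", "known", "first", "only" and "open" are said of these compounds alone.

Measured compounds:
- compound 1 `COc1ccc(-c2c(Cl)c(=O)c3c(OC)cc(OC)cc3n2S(=O)(=O)c2ccc(OC)cc2)cc1` — "not determined" (no result reported)
- compound 2 `COc1ccc(-c2c(Br)c(=O)c3c(OC)cc(OC)cc3n2S(=O)(=O)c2ccc(OC)cc2)cc1` — 69000 nM
- compound 3 `COc1ccc(-c2[nH]c3cc(OC)cc(OC)c3c(=O)c2I)cc1` — "not determined" (no result reported)

In an ADME assay on THLE-2 cells (Homo sapiens) for antiproliferative activity, with a stated time of 72 h (on this read-out higher numbers stand for an effect only at larger amounts of compound and lower numbers for an effect already at smaller amounts), compound 2 gives 69000 nM. On this read-out compound 3 gives "not determined" (no result reported), and compound 1 gives "not determined" (no result reported); so compound 3 stands unplaced relative to anything measured, and no comparison of its own can be drawn.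

Compound 4 `COc1ccc(-c2c(I)c(=O)c3c(OC)cc(OC)cc3n2S(=O)(=O)c2ccc(OC)cc2)cc1` is the next entry. Relative to compound 3 the change is (4-methoxyphenyl)sulfonyl in place of hydrogen on an aromatic nitrogen, and the iodo group stays in place. Within the data shown here, no measured step covers this change, so its size is not known from any pair in hand; compound 4 shares with compound 2 the (4-methoxyphenyl)sulfonyl on the aromatic nitrogen, which is the only anchor available. The expectation for this assay is therefore a step of no defined direction beyond the usual scatter, anchored on compound 2 alone.

Compound 4 is estimated at 60000 nM in this assay, with a range from 25000 nM to 150000 nM.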

Compound 4, half-maximal effective concentration: 57000 nM
Beside the measured number, compound 4's estimate is 1.1-fold (0.02 log units) above it, and the stated range covers the measured number.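

In this assay, among these compounds, iodo in place of bromo on the aromatic carbon gives a 1.2-fold lower number from compound 2 to compound 4 (0.08 log units; within the scatter), the first readable step, so with (4-methoxyphenyl)sulfonyl on the aromatic nitrogen these two halogens are not told apart on this read-out. The step that adds (4-methoxyphenyl)sulfonyl in place of hydrogen on the aromatic nitrogen cannot be read, since compound 3 has no single number to set against compound 4. No supporting data bear on the reason for this result.

From the compounds shown here alone, whether the read-out at the aromatic carbon stays as flat holds only for the bromo and iodo pair; an amine or a carboxylic acid there remains open. Also open, going by these compounds, is how a longer alkyl chain on the sulfonyl would read in place of the 4-methoxyphenyl group.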